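The source may report more compounds than this note shows. Statements on the series, on what has been measured and on what is new or still open speak of the compounds shown alone.

Measured compounds:
compound 1 `CCCCc1nc(N)c2nc(O)n(Cc3ccccc3)c2n1` – 0.03 uM
compound 2 `CCCc1nc(N)c2nc(O)n(Cc3ccccc3)c2n1` – 1 uM

In a functional assay (spleen, spleen) for activation, with Mus musculus as the target (a lower number here means that less compound is needed, a higher number that more compound is needed for the effect), compound 2 gives the highest of the two numbers; the nearest is compound 1, and the step of a 33-fold higher number from compound 1 to compound 2 (1.52 log units; beyond the scatter) is the only one recorded. Compound 3 `CCCNc1nc(N)c2nc(O)n(Cc3ccccc3)c2n1` differs from compound 2 by propylamino in place of propyl on an aromatic carbon. Among the measured compounds shown here, no measured step changes a chain into an amino-bearing chain at this position, so the single step from compound 1 to compound 2 shows only that the position answers strongly to change, not in which direction. The expected step in this assay is therefore no change at the digits printed from compound 2 to compound 3 (within the scatter), with a wide range. Compound 3 is estimated at 1 uM, from 0.1 uM to 10 uM.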

Compound 3, minimum effective concentration: 0.1 uM
For compound 3 the middle estimate is 10-fold (1.00 log units) above the measured one, within the range that was stated.
By their numbers in this assay, from the lowest: compound 1; then compound 3; then compound 2.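

In this assay, propylamino in place of propyl on this aromatic carbon gives (a 10-fold lower number from compound 2 to compound 3 (1.00 log units; beyond the scatter)), so a chain joined through nitrogen recovers much of what the shorter propyl chain loses. The recovery is incomplete, since propylamino in place of butyl gives (a 3.3-fold higher number from compound 1 to compound 3 (0.52 log units; beyond the scatter)), and butyl keeps the lowest number of the three. No evidence on the origin of either step is at hand. Open, as far as these compounds go, is whether butylamino or a longer chain such as pentyl goes lower still, and whether an oxygen-linked butoxy chain behaves like the amino-linked one.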